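Isopropyl to propyl on a saturated ring carbon

The source may hold more compounds than are shown below. What is called first, only, known or untested is meant among the compounds shown, and "the series" means these compounds.

In an in vivo ADME assay on the whole organism (strain Sprague-Dawley) for pharmacokinetics, with Rattus norvegicus as the target (a higher number here means that more of the compound sits outside the plasma, a lower number that more of the compound stays in the plasma), compound 1 `CC(C)[C@@H]1NC[C@@H](C)Oc2ccccc2CCCNC(=O)[C@@H](Cc2ccc(F)cc2)NC(=O)[C@@H](C)N(C)C1=O` gives 2 L/kg. Compound 2 `C[C@@H]1C(=O)N[C@H](Cc2ccc(F)cc2)C(=O)NCCCc2ccc(F)cc2OCCN[C@@H](C2CC2)C(=O)N1C` gives 1.8 L/kg. Within the data shown here, these two numbers lie within the usual scatter of repeated measurements, so compound 1 stands level with the only other compound measured so far.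

Compound 3 `CCC[C@@H]1NC[C@@H](C)Oc2ccccc2CCCNC(=O)[C@@H](Cc2ccc(F)cc2)NC(=O)[C@@H](C)N(C)C1=O` has not been measured yet. It has the same atoms as compound 1, joined differently: propyl in place of isopropyl on a saturated ring carbon. Put simply, propyl takes the place of isopropyl on a saturated ring carbon, next to the ring nitrogen, while the rest of the molecule stays the same.

Among the measured compounds shown here, the two measured compounds offer no step that tests this swap directly, so the data cannot show how much it matters. The expectation therefore starts from compound 1 at 2 L/kg. In this assay, no shift beyond the scatter is expected in either direction, and the expected step is a 1.1-fold higher number from compound 1 to compound 3 (0.02 log units; within the scatter). For compound 3 the estimate is 2.1 L/kg, with an expected range from 1.1 L/kg to 3.8 L/kg.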

Compound 3, volume of distribution at steady state: 1.7 L/kg
The estimate for compound 3 lay 1.2-fold (0.09 log units) above the measured number, and the stated range covers the measured number.
By their numbers in this assay, from the lowest: compounds 3, 2 and 1 (each within the scatter of the next).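

In this assay, the swap of isopropyl for propyl on this saturated ring carbon gives a 1.2-fold lower number from compound 1 to compound 3 (0.07 log units; within the scatter). Among these compounds, this is the first direct test at this position, and it shows that rearranging the same three carbons from a branched group into an unbranched chain leaves compound 3 level with compound 1, with the rest of the molecule held constant. Nothing measured here speaks to why the two compounds stand level.

The comparison covers only two arrangements of one small carbon group in a single read-out, so it says nothing about how far this tolerance extends at the position, and compound 2, which differs from both compounds in more than one place, cannot settle that. As far as these compounds go, whether a longer chain such as butyl, or a group carrying an amine or a carboxylic acid, would also stand level with compound 1 on this ring carbon remains open.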